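Trifluoromethyl in Place of Nitro: What to Expect

This account rests on a few compounds, and the source may have more. Where it says the series, first, only, none or still open, it means among the compounds named here.

Three esters built on one shared core have been tested in a functional assay on PC-3 cells (Homo sapiens) for antiproliferative activity, read by sulforhodamine B assay, with a stated time of 48 h, tested at 50 uM; a higher number here means more inhibition at the concentration tested (going by the name of the read-out), a lower number less inhibition. Compound 1 `COc1ccc(C(=O)Oc2cc3c(cc2C)[C@@H](C(C)C)CC=C3C)cc1` gives 60.6%. Compound 2 `CC1=CC[C@H](C(C)C)c2cc(C)c(OC(=O)c3ccc(Cl)cc3)cc21` gives 34.1%, and compound 3 `CC1=CC[C@H](C(C)C)c2cc(C)c(OC(=O)c3ccc([N+](=O)[O-])cc3)cc21` gives 36.7%. Among these three numbers compound 3 stands second highest; its nearest neighbour is compound 2, and the step of a number 2.6 percentage points higher from compound 2 to compound 3 (within the scatter) lies within the scatter, while a number 23.9 percentage points lower from compound 1 to compound 3 (beyond the scatter) and a number 26.5 percentage points lower from compound 1 to compound 2 (beyond the scatter) both lie beyond it. The next compound, compound 4 `CC1=CC[C@H](C(C)C)c2cc(C)c(OC(=O)c3ccc(C(F)(F)F)cc3)cc21`, differs from compound 3 by trifluoromethyl in place of nitro on an aromatic carbon. Going by the values given here, no measured step exchanges nitro for trifluoromethyl, so the closest guide is the exchange of chloro for nitro, a number 2.6 percentage points higher from compound 2 to compound 3 (within the scatter), which changed little, whereas leaving methoxy cost a modest amount in both a number 26.5 percentage points lower from compound 1 to compound 2 (beyond the scatter) and a number 23.9 percentage points lower from compound 1 to compound 3 (beyond the scatter). Since chloro and nitro both land well below methoxy and close to each other, a further exchange at that place is expected to give a step of a number 0.7 percentage points lower from compound 3 to compound 4 (within the scatter) that stays within the scatter. Compound 4 is therefore estimated at 36%, in the range 22% to 50%.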

Compound 4, a percentage reported as inhibition, at one concentration (the size of the read-out at that concentration, not a potency): 12.3%
The estimate for compound 4 lay 23.7 percentage points above the measured number; the whole stated range lies above it.
By their numbers in this assay, from the lowest: compound 4; then compounds 2 and 3 (each within the scatter of the next); then compound 1.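

Trifluoromethyl does not behave like the other two replacements for methoxy at this aromatic carbon: swapping it for nitro gives a number 24.4 percentage points lower from compound 3 to compound 4 (beyond the scatter), and swapping it for chloro gives a number 21.8 percentage points lower from compound 2 to compound 4 (beyond the scatter), so this place distinguishes groups beyond the near-equal pair seen so far. Measured against methoxy, the change gives a number 48.3 percentage points lower from compound 1 to compound 4 (beyond the scatter), and the four compounds now fall into three levels rather than two, with compounds 2 and 3 together in the middle. Going by these compounds alone, nothing available here explains why trifluoromethyl lowers the number so far.

As far as these compounds go, it remains open whether an amine, a carboxylic acid or a longer chain such as ethoxy at this place would land nearer compound 1 or nearer compound 4. From the compounds shown here alone, each number also comes from a single concentration, so how these differences would translate into potency also stays open.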